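The source may report more compounds than this note shows. Statements on the series, on what has been measured and on what is new or still open speak of the compounds shown alone.

Measured compounds:
- compound 1, `COc1ccc(Oc2ccc3cc(NC(=O)c4ccc(O)c(CC=C(C)C)c4)c(=O)oc3c2C)cc1`: 6510 nM in a functional assay on MCF7 cells (Homo sapiens) for antiproliferative activity; on this read-out lower numbers stand for stronger inhibition and higher numbers for weaker inhibition
- compound 2, `COc1cccc(Oc2ccc3cc(NC(=O)c4ccc(OC(C)=O)c(CC=C(C)C)c4)c(=O)oc3c2C)c1`: 15700 nM in this assay

Compound 2 stands highest of the two numbers; its nearest neighbour is compound 1, whose number lies lower by a gap beyond the usual scatter. The two compounds differ in two places, so the gap cannot be assigned to either change alone.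

Compound 3, `COc1cccc(Oc2ccc3cc(NC(=O)c4ccc(O)c(CC=C(C)C)c4)c(=O)oc3c2C)c1`, is not yet measured. It follows from compound 2 by a single change: hydrogen in place of acetyl on an oxygen on an aromatic ring. Among the compounds with values here, no measured pair shows this step on its own. In compound 1 the same oxygen carries a hydrogen, and compound 1 gives the lower number of the two, so the expectation leans toward a lower number for compound 3 than for compound 2, with a step of a 2.2-fold lower number from compound 2 to compound 3 (0.35 log units; beyond the scatter) that is expected to exceed the scatter but remain modest.

The expected value for compound 3 in this assay is 7000 nM, with a range from 2500 nM to 20000 nM.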

Compound 3, half-maximal inhibitory concentration: 62800 nM
For compound 3 the middle estimate is 9.0-fold (0.95 log units) below the measured one; measured number outside the range, above it.
By their numbers in this assay, from the lowest: compound 1; then compound 2; then compound 3.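

In this assay, with 3-methoxyphenyl held fixed, acetoxy to hydroxy gives a 4.0-fold higher number from compound 2 to compound 3 (0.60 log units; beyond the scatter) and so the hydroxy form is the weaker of this pair, a direction that compound 1 and compound 2 alone could not show. With hydroxy held fixed, 3-methoxyphenyl in place of 4-methoxyphenyl on the oxygen gives a 9.6-fold higher number from compound 1 to compound 3 (0.98 log units; beyond the scatter) and so the methoxyphenyl change alone also moves the number well beyond the scatter, with the 4-methoxyphenyl form giving the stronger inhibition. No measurement shown here accounts for either step.

From the compounds shown here alone, whether acetoxy to hydroxy runs in the same direction with 4-methoxyphenyl in place remains open. Also open, going by these compounds, is how this aromatic oxygen responds to a methyl ether or to a longer acyl chain such as butanoyl.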